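Oxazoline to thiazoline swap on two isoxazoline sulfone cores

A few compounds are considered here, and "the series" means these few. Any claim that something is new, unique, unknown or untested is made for them only; others in the source may bear on it.

Compound 2 `COc1ccc(C2=NOC(c3ccc(C)cc3)C2S(=O)(=O)CC2=NCCO2)cc1` and compound 3 `COc1ccc(C2=NOC(c3ccc(C)cc3)C2S(=O)(=O)CC2=NCCS2)cc1` share one core and differ only by a group of 5 heavy atoms (3 carbon, 1 nitrogen, 1 sulfur; one five-membered non-aromatic ring with 2 hetero atoms) in place of a group of 5 heavy atoms (3 carbon, 1 nitrogen, 1 oxygen; one five-membered non-aromatic ring with 2 hetero atoms), on a saturated chain carbon bound to a sulfonyl sulfur. In a functional assay, tested at 50 ug/mL (a lower number here means a weaker effect, a higher number a stronger effect of the compound at the concentration tested), compound 2 gives 65.9% and compound 3 gives 47.5%, so the change brought a number 18.4 percentage points lower from compound 2 to compound 3 (beyond the scatter).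

Compound 1 `O=S(=O)(CC1=NCCO1)C1C(c2ccc(Cl)cc2)=NOC1c1ccc(Cl)cc1` carries a second core; the difference between the two cores is not broken down here. In this assay compound 1 is reported as "not active" (no number reported), with no number given. Compound 4 `O=S(=O)(CC1=NCCS1)C1C(c2ccc(Cl)cc2)=NOC1c1ccc(Cl)cc1` is related to compound 1 by a group of 5 heavy atoms (3 carbon, 1 nitrogen, 1 sulfur; one five-membered non-aromatic ring with 2 hetero atoms) in place of a group of 5 heavy atoms (3 carbon, 1 nitrogen, 1 oxygen; one five-membered non-aromatic ring with 2 hetero atoms), on a saturated chain carbon bound to a sulfonyl sulfur, the same change seen from compound 2 to compound 3.

Within the measured pair the change lowered the read-out by a modest, if real, amount. Because compound 1 already shows "not active" (no number reported) in this assay, there is little room for a further drop to appear as a number, and the measured pair offers no sign that the change raises activity. Compound 4 is therefore expected to be weak in this assay, around 8%, most likely between 0% and 22%, and it may well again be reported only as inactive.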

Compound 4, a percentage reported as activity, at one concentration (the size of the read-out at that concentration, not a potency): "not active" (no number reported)
The entry for compound 4 holds no number; the estimate stays without a comparison.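

In this assay compound 1 gives "not active" (no number reported) and compound 4 gives "not active" (no number reported), so no step can be read between them. Nothing available here bears on this result. The two compounds leave open what size of effect, if any, the change of the five-membered ring has on the core of compound 1.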